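Moving the Chlorine Around the Phenyl Ring

The source may hold more compounds than are shown below. What is called first, only, known or untested is meant among the compounds shown, and "the series" means these compounds.

Compound 1 `CCCn1c(=O)[nH]c2nc(-c3ccc(S(=O)(=O)N4CCN(c5cccc(Cl)c5)CC4)cc3)[nH]c2c1=O`: > 1000 nM, a limit of the assay
Compound 2 `CCCn1c(=O)[nH]c2nc(-c3ccc(S(=O)(=O)N4CCN(c5ccc(C)cc5)CC4)cc3)[nH]c2c1=O`: > 1000 nM, a limit of the assay

Both measured compounds share one core and differ only in the aryl group on the ring amine nitrogen. In an assay on CHO cells for displacement of a labelled ligand from adenosine receptor A1 (Homo sapiens), read by scintillation counting, with a stated time of 90 min, in the presence of a further agent that is not named here (on this read-out lower numbers stand for stronger inhibition and higher numbers for weaker inhibition), compound 1 reaches only the limit > 1000 nM. Compound 2 likewise gives no number in this assay but the limit > 1000 nM. The step that the two limits leave unreadable from compound 1 to compound 2 therefore cannot be read, because both values rest on (the limit of > 1000 nM in this assay, at which 2 of the 2 values shown sit). Compound 2 thus stands nowhere definite on the numbers shown: it is a limit alongside another limit.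

Compound 3 `CCCn1c(=O)[nH]c2nc(-c3ccc(S(=O)(=O)N4CCN(c5ccccc5Cl)CC4)cc3)[nH]c2c1=O` differs from compound 2 by 2-chlorophenyl in place of 4-methylphenyl on an amine nitrogen in a ring. Going by the values given here, the one measured step bears on this change only by showing that neither aryl group so far has lifted binding into the readable range. No direction can be read from it. Compound 3 is expected to show 3000 nM, between 800 nM and 15000 nM. The expected step that the limit leaves unreadable from compound 2 to compound 3 is accordingly estimated as nothing beyond the scatter, and a further limit is the most likely outcome.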

Compound 3, inhibition constant: > 1000 nM
Compound 3 gave a limit, no number (the forecaster's own chance of this, stated with the estimate: 80%); the middle value does not contradict the limit.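

Compound 3 also gives only a limit, so neither the step from compound 1 to compound 3 nor the step from compound 2 to compound 3 can be read: (the limit of > 1000 nM in this assay, at which 3 of the 3 values shown sit). The compounds shown leave open how 2-chlorophenyl, 3-chlorophenyl and 4-methylphenyl rank against one another in this assay and whether any aryl group on this ring nitrogen gives a readable value.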